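A few compounds are considered here, and "the series" means these few. Any claim that something is new, unique, unknown or untested is made for them only; others in the source may bear on it.

Measured in a functional assay on A549 cells (Homo sapiens) for antiproliferative activity, read by sulforhodamine B assay, with a stated time of 3 days; on this read-out higher numbers stand for an effect only at larger amounts of compound and lower numbers for an effect already at smaller amounts:

- Compound 1 `CCCC1=C(OCC(C)C)C(CCC)(CCC)C(=O)/C(=C(O)\C=C\c2ccccc2)C1=O`: 1.7 uM
- Compound 2 `CCCCC1=C(OC)C(CCCC)(CCCC)C(=O)/C(=C(O)\C=C\c2ccccc2)C1=O`: 6.4 uM

Compound 1 holds the lower of these two numbers, and its gap to compound 2 lies beyond the usual scatter. Compound 3 `CCCC1=C(OCC)C(CCC)(CCC)C(=O)/C(=C(O)\C=C\c2ccccc2)C1=O` keeps the core of compound 1 and alters a single group: methyl in place of isopropyl on a saturated chain carbon bound to an oxygen on an unsaturated carbon. This puts methyl in place of isopropyl on a saturated chain carbon bound to an oxygen on an unsaturated carbon, so isobutoxy becomes ethoxy. For the measured compounds named here, no pair of measured compounds isolates this change. Compound 2 gives 6.4 uM, but it differs from compound 1 in more than one place, so it is only a weak guide. A modest rise in the number in this assay is therefore expected, close to the edge of the scatter. The expected step is a 1.8-fold higher number from compound 1 to compound 3 (0.25 log units; within the scatter). The estimate for compound 3 is 3 uM, with an expected range from 1 uM to 9 uM.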

Compound 3, concentration for half-maximal effect: 4.6 uM
Beside the measured number, compound 3's estimate is 1.5-fold (0.19 log units) below it; the measured number falls inside the stated range.
By their numbers in this assay, from the lowest: compound 1; then compounds 3 and 2 (each within the scatter of the next).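

In this assay, changing isobutoxy to ethoxy, with the rest of the molecule untouched, gives a 2.7-fold higher number from compound 1 to compound 3 (0.43 log units; beyond the scatter). This is the only step shown that isolates this position, and it shows that the group on this oxygen matters in this assay: putting methyl in place of isopropyl moves the number beyond the usual scatter. In this single pair, the larger group goes with the lower number, but nothing available explains the step.

Going by these compounds, two groups at one place make a comparison, not a trend, so it remains open what a longer chain such as hexyloxy, a benzyloxy group, or a chain ending in an amine would give. On these data alone, it is also open whether the same change would give a similar step with the butyl chains of compound 2 in place of the propyl chains.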